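A few compounds are considered here, and "the series" means these few. Any claim that something is new, unique, unknown or untested is made for them only; others in the source may bear on it.

In a functional assay on PC-3 cells (Homo sapiens) for cytotoxicity, read by MTT assay, with a stated time of 72 h (on this read-out lower numbers stand for stronger inhibition and higher numbers for weaker inhibition), compound 3 `CNC(=O)c1cc(Oc2ccc(NC(=O)c3cc(-c4ccc(Br)cc4)ncn3)cc2F)ccn1` gives > 100000 nM as a limit and not a number. Compound 1 `CNC(=O)c1cc(Oc2ccc(NC(=O)c3cc(-c4ccc(C)cc4)ncn3)cc2)ccn1` likewise gives > 100000 nM as a limit. Only compound 2 `CCc1ccc(-c2cc(C(=O)Nc3ccc(Oc4ccnc(C(=O)NC)c4)c(F)c3)ncn2)cc1` returns a true number, with 15600 nM as its result. Compound 4 `CNC(=O)c1cc(Oc2ccc(NC(=O)c3cc(-c4ccc(C)cc4)ncn3)cc2F)ccn1` departs from compound 3 by methyl in place of bromo on an aromatic carbon in one place, with methyl in place of bromo on an aromatic carbon, para to a large group. Going by the values given here, one measured step bears on this place, namely an at least 6.4-fold higher number from compound 2 to compound 3 (0.80 log units; beyond the scatter) for bromo in place of ethyl, and it lies beyond the scatter. Losing bromo is therefore expected to lower the number in this assay modestly, with an at least 2.2-fold lower number from compound 3 to compound 4 (0.34 log units; beyond the scatter) as the estimated step, though another limit remains quite possible. For compound 4 the estimated value is 45000 nM with an expected range from 12000 nM to 120000 nM at the upper end.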

Compound 4, half-maximal inhibitory concentration: 40200 nM
Beside the measured number, compound 4's estimate is 1.1-fold (0.05 log units) above it; the range from low to high includes it.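

In this assay, the change to 4-methylphenyl gives an at least 2.4-fold lower number from compound 3 to compound 4 (0.39 log units; beyond the scatter), while methyl in place of ethyl gives a 2.6-fold higher number from compound 2 to compound 4 (0.41 log units; beyond the scatter), so among these three groups at this position methyl falls between ethyl and bromo. Fluoro on the core also counts here, with an at least 2.4-fold lower number from compound 1 to compound 4 (0.39 log units; beyond the scatter). Two of these steps are only bounds: the limit of > 100000 nM in this assay, at which 2 of the 4 values shown sit.

Going by these compounds, how far the order extends to a longer chain such as propyl, or to a methoxy group, stays open. On these data alone, the true sizes of the two bounded steps also stay open.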